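Extending the carboxy chain of compound 2

This account rests on a few compounds, and the source may have more. Where it says the series, first, only, none or still open, it means among the compounds named here.

In a functional assay on KB cells (Homo sapiens) for inhibition, read by CellTiter-Blue, with a stated time of 96 h, in the presence of a further agent that is not named here (a higher number here means a weaker inhibitor, a lower number a stronger inhibitor), compound 1 `Nc1nc2[nH]c(CCCCCC(=O)N[C@@H](CCC(=O)O)C(=O)O)cc2c(=O)[nH]1` gives > 1000 nM, which is a limit of the assay and not a number. Compound 2 `Nc1nc2[nH]c(CCCCCC(=O)O)cc2c(=O)[nH]1` gives > 1000 nM, which is also only a limit, so its true position is not known. Compound 3 `Nc1nc2[nH]c(CCCCCCC(=O)O)cc2c(=O)[nH]1` differs from compound 2 in one place: carboxymethyl in place of carboxy on a saturated chain carbon, five bonds along the chain from an aromatic carbon, with carboxymethyl in place of carboxy on a saturated chain carbon, five bonds along the chain from an aromatic carbon. The step expected a step that the limit leaves unreadable from compound 2 to compound 3 in this assay is none beyond the usual scatter. For compound 3, the estimated value is 1500 nM, with an expected range from 800 nM to 5000 nM.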

Compound 3, half-maximal inhibitory concentration: > 1000 nM
Compound 3: a limit, no number; the forecaster's own chance of this, stated with the estimate: 90%; the middle value does not contradict the limit.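

No step can be read from compound 2 to compound 3, since both values are limits and not numbers: the limit of > 1000 nM in this assay, at which 3 of the 3 values shown sit.

The compounds shown leave open how strongly each one actually inhibits, and whether carboxymethyl in place of carboxy changes that at all.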